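Opening the Sulfonyl Piperazine Ring of a Weak Binder

This account rests on a few compounds, and the source may have more. Where it says the series, first, only, none or still open, it means among the compounds named here.

Of the compounds shown here, three built on one shared core have been measured in an assay on HEK293 cells for displacement of a labelled ligand from NPC1-like intracellular cholesterol transporter 1 (Homo sapiens); on this read-out lower numbers stand for stronger inhibition and higher numbers for weaker inhibition. Compound 1, `CC(C)(C)OC(=O)NC1CCN(C(=O)CN2CN(c3ccccc3)C3(CCN(C(=O)c4ccc(C(C)(C)C)cc4)CC3)C2=O)CC1`, gives 8300 nM. Compound 3, `CC(C)(C)OC(=O)NC1CCCN(C(=O)CN2CN(c3ccccc3)C3(CCN(C(=O)c4ccc(C(C)(C)C)cc4)CC3)C2=O)C1`, gives 4200 nM. Going by the values given here, compound 2, `CC(C)(C)c1ccc(C(=O)N2CCC3(CC2)C(=O)N(CC(=O)N2CCN(S(C)(=O)=O)CC2)CN3c2ccccc2)cc1`, gives 19000 nM, the highest of the three numbers, which on this read-out means the weakest binding of the three; its gap to compound 1 and its gap to compound 3 both lie beyond the usual scatter, so compound 2 is the least potent compound measured so far.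

Compound 4, `CC(C)(C)c1ccc(C(=O)N2CCC3(CC2)C(=O)N(CC(=O)NCNS(C)(=O)=O)CN3c2ccccc2)cc1`, has not yet been measured. It differs from compound 2 in one place: ((methanesulfonamido)methyl)amino in place of 4-(methylsulfonyl)piperazin-1-yl on a carbonyl carbon. In plain terms, the six-membered ring is opened into a short chain that keeps the sulfonyl part and gains two hydrogen-bond donors.

No measured pair among these three compounds shows a change of this kind, so nothing here tells how far such a change moves the number. The expected step is therefore a modest one, a 1.2-fold lower number from compound 2 to compound 4 (0.07 log units; within the scatter), not reaching beyond the scatter. For compound 4 the estimated value is 16000 nM, with a range from 5000 nM to 50000 nM.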

Compound 4, half-maximal inhibitory concentration: 3200 nM
For compound 4 the middle estimate is 5.0-fold (0.70 log units) above the measured one, and the stated range ends above it.
By their numbers in this assay, from the lowest: compounds 4, 3 and 1 (each within the scatter of the next, the first and the last beyond it); then compound 2.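

Replacing 4-(methylsulfonyl)piperazin-1-yl with ((methanesulfonamido)methyl)amino on a carbonyl carbon gives, in this assay, a 5.9-fold lower number from compound 2 to compound 4 (0.77 log units; beyond the scatter), a clear gain in binding strength, so the closed six-membered ring is not needed here and this position responds to the group it carries. Going by these compounds alone, the single step changes several things at once: the entering group has no ring, fewer heavy atoms, and 2 hydrogen-bond donors instead of 0, while the count of hydrogen-bond acceptors stays the same, so the pair cannot show which of these differences matters. Nothing available here explains the gain.

The compounds shown leave open whether the sulfonyl part is still needed in the opened chain, which a simple acetamide in place of the methanesulfonamide end could test. They also leave open how the number responds to a longer chain, such as an ethylene link in place of the single methylene, or to a methyl group in place of either amide or sulfonamide hydrogen.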